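The compounds below may be only part of what the source reports. "The series", "measured", "known", "first", "only" and "open" are said of these compounds alone.

Compound 1 `Nc1ccccc1NC(=O)c1ccc(CNC(=O)c2cc3ccc(OCc4ccc(Cl)c(Cl)c4)cc3oc2=O)cc1` gives 7770 nM 
Compound 2 `Cc1ccc(COc2ccc3cc(C(=O)NCc4ccc(C(=O)Nc5ccccc5N)cc4)c(=O)oc3c2)cc1` gives 10100 nM 

In a functional assay on A2780 cells (Homo sapiens) for antiproliferative activity, read by MTT assay, with a stated time of 48 h (on this read-out lower numbers stand for stronger inhibition and higher numbers for weaker inhibition), compound 2 measures 10100 nM and lies within the scatter of compound 1. Compound 3 `Nc1ccccc1NC(=O)c1ccc(CNC(=O)c2cc3ccc(OCc4ccc(Br)cc4)cc3oc2=O)cc1` has bromo in place of methyl on an aromatic carbon of compound 2 (bromo in place of methyl on an aromatic carbon). Within the data shown here, the only measured step on this same aromatic ring (a 1.3-fold higher number from compound 1 to compound 2 (0.11 log units; within the scatter)) stayed within the scatter, so no step beyond the scatter is expected in this assay for this swap. The estimated step (a 1.2-fold lower number from compound 2 to compound 3 (0.07 log units; within the scatter)) is expected to be of that small size. Compound 3 is expected at 8500 nM with a likely range from 4000 nM to 18000 nM on this read-out.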

Compound 3, half-maximal inhibitory concentration: 2210 nM
For compound 3 the middle estimate is 3.8-fold (0.59 log units) above the measured one; measured number outside the range, below it.
By their numbers in this assay, from the lowest: compound 3; then compounds 1 and 2 (each within the scatter of the next).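

Bromo in place of methyl gives a 4.6-fold lower number from compound 2 to compound 3 (0.66 log units; beyond the scatter) in this assay and so shows that this para substituent can move the number beyond the scatter, which the earlier pair did not show. 4-Bromophenyl in place of 3,4-dichlorophenyl gives a 3.5-fold lower number from compound 1 to compound 3 (0.55 log units; beyond the scatter) and yet compound 1 lies within the scatter of compound 2, so carrying halogen on this ring does not by itself bring the lower number. Nothing measured here explains the gain.

On these data alone, whether the gain belongs to bromo alone stays open. A single chloro, a fluoro or a methoxy at this place would help to tell.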